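Morpholine for the Diol Chain on the Shared Core

This account rests on a few compounds, and the source may have more. Where it says the series, first, only, none or still open, it means among the compounds named here.

Compound 1 `NC(=O)c1cc(-c2ccc(NS(=O)(=O)c3cccc(Cl)c3Cl)cc2)nc2[nH]ncc12` gives 1 nM in an assay for inhibition of serine/threonine-protein kinase Sgk1 (Homo sapiens), with stated times of 30 min and 60 min, in the presence of a further agent that is not named here; on this read-out lower numbers stand for stronger inhibition and higher numbers for weaker inhibition. Compound 2 `CN1CC(NC(=O)c2cc(-c3ccc(NS(=O)(=O)c4cccc(Cl)c4Cl)cc3)nc3[nH]ncc23)C1` reaches a limit of the assay, < 1 nM. Among the compounds with values here, the one measured step, a number no higher from compound 1 to compound 2 (the limit leaves the size open), sits at the limit of < 1 nM in this assay, at which 1 of the 3 values shown sits, and leaves its size open; it concerns an amide nitrogen, not the chain changed here. Compound 3 `Cc1n[nH]c2nc(-c3ccc(NS(=O)(=O)c4cc(Cl)ccc4F)cc3)nc(OCC(CO)CO)c12` stands level with compound 1 at the digits shown; in this assay compound 3 gives 1 nM. Compound 4 `Cc1n[nH]c2nc(-c3ccc(NS(=O)(=O)c4cc(Cl)ccc4F)cc3)nc(OCC3CNCCO3)c12` differs from compound 3 by morpholin-2-yl in place of 2-hydroxy-1-(hydroxymethyl)ethyl on a saturated chain carbon bound to an oxygen on an aromatic ring. Within the data shown here, no measured step touches that place, so the expectation rests on compound 3 alone, and the expected change is a 1.2-fold higher number from compound 3 to compound 4 (0.08 log units; within the scatter), nothing beyond the scatter. Compound 4 is therefore estimated at 1.2 nM, between 0.4 nM and 4 nM.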

Compound 4, half-maximal inhibitory concentration: 2 nM
Beside the measured number, compound 4's estimate is 1.7-fold (0.22 log units) below it; the range from low to high includes it.
By their numbers in this assay, from the lowest: compounds 1, 3 and 4 (each within the scatter of the next).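

Within the data shown here, the first measured step at this place shows that the open diol chain can give way to a ring holding a nitrogen: in this assay there is a 2.0-fold higher number from compound 3 to compound 4 (0.30 log units; within the scatter). Among these compounds, the number therefore stays within the scatter on a change of both size and ring content, which the earlier compounds did not test here. The read-out has little room on its lower side: the limit of < 1 nM in this assay, at which 1 of the 4 values shown sits.

On these data alone, what a carboxylic acid or a piperidine ring would give at this place stays open. So does whether the same exchange would hold on the core of compound 1.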